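Propyl to Octyl: Does the Longer Chain Stay Tolerated?

This account rests on a few compounds, and the source may have more. Where it says the series, first, only, none or still open, it means among the compounds named here.

Compound 2 `CCCSc1nc(N)nc2c1ncn2/C=C1/CC1(CO)CO` is known in an ADME assay on HFF cells (Homo sapiens) for cytotoxicity, with a stated time of 8 days (a higher number here means that more compound is tolerated, a lower number that less compound is tolerated), only as a limit. In this assay compound 2 gives > 300000 nM, a limit of the assay and not a number. Compound 1 `CCOc1nc(N)nc2c1ncn2/C=C1/CC1(CO)CO` stands in the same position. In this assay compound 1 gives > 300000 nM, again a limit. Among the compounds with values here, the single measured step, a step that the two limits leave unreadable from compound 1 to compound 2, thus has no readable size, since the limit of > 300000 nM in this assay, at which 2 of the 2 values shown sit, covers both values. Compound 3 `CCCCCCCCSc1nc(N)nc2c1ncn2/C=C1/CC1(CO)CO` differs from compound 2 by pentyl in place of hydrogen on a saturated chain carbon, three bonds along the chain from a sulfur, propyl to octyl. Within the data shown here, no measured step speaks readably to this change, so no direction can be drawn. Compound 3 is expected to give 300000 nM, within 100000 nM to 600000 nM. The implied step, a number no higher from compound 2 to compound 3 (the limit leaves the size open), is an estimate only.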

Compound 3, half-maximal cytotoxic concentration: > 300000 nM
Compound 3 ended at the assay's limit (the forecaster's own chance of this, stated with the estimate: 60%); the middle value lies on the limit itself.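

The steps among compound 1, compound 2 and compound 3 cannot be read in this assay, because all three sit at one limit of the assay: the limit of > 300000 nM in this assay, at which 3 of the 3 values shown sit. The compounds shown leave open whether the change from propyl to octyl alters tolerance at all.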